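A few compounds are considered here, and "the series" means these few. Any claim that something is new, unique, unknown or untested is made for them only; others in the source may bear on it.

Measured compounds in a functional assay on B16 cells (Mus musculus) for cytotoxicity, read by MTT assay, with a stated time of 48 h; a higher number here means a weaker inhibitor, a lower number a stronger inhibitor:

Compound 1 `O=[N+]([O-])c1ccc(-c2cn(Cc3ccccc3)nn2)cc1` gives 5120 nM.
Compound 2 `OC(c1ccc(C(F)(F)F)cc1)c1cn(Cc2ccccc2)nn1` gives > 100000 nM.
Compound 3 `CC1(C)OCC(Cn2cc(-c3ccc([N+](=O)[O-])cc3)nn2)O1` gives > 100000 nM.

The value of compound 2 is a limit of the assay, not a number. The value of compound 3 is likewise a limit, not a number. Compound 1 and compound 2 share a triazole bearing a benzyl group, but the difference between their two cores is not broken down here.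

Compound 3 arises from compound 1 by one change, (2,2-dimethyl-1,3-dioxolan-4-yl in place of phenyl on a saturated chain carbon bound to an aromatic nitrogen), and this change gave an at least 19-fold higher number from compound 1 to compound 3 (1.29 log units; beyond the scatter). Compound 4 `CC1(C)OCC(Cn2cc(C(O)c3ccc(C(F)(F)F)cc3)nn2)O1` is not yet measured; it arises from compound 2 by the same change, (2,2-dimethyl-1,3-dioxolan-4-yl in place of phenyl on a saturated chain carbon bound to an aromatic nitrogen), at the same place in the molecule.

Compound 2 already sits at the limit of > 100000 nM in this assay, at which 2 of the 3 values shown sit. Since the same change weakened compound 1 sharply in an at least 19-fold higher number from compound 1 to compound 3 (1.29 log units; beyond the scatter), compound 4 is expected to remain beyond that limit. The expected step is a step that the limit leaves unreadable from compound 2 to compound 4. Compound 4 is estimated at 300000 nM, between 100000 nM and 3000000 nM.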

Compound 4, half-maximal inhibitory concentration: > 100000 nM
Compound 4: only a limit was reported (the forecaster's own chance of this, stated with the estimate: 90%); the middle value lies beyond the limit too.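

In this assay, for the compounds shown here, compound 2 and compound 4 each stand only as a limit of the assay, not as a number, so no step between them can be read. The compounds shown leave open how strongly either compound acts, and whether 2,2-dimethyl-1,3-dioxolan-4-yl in place of phenyl changes the number at all on this core.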